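One Methyl Group Added to the Weaker Compound

A few compounds are considered here, and "the series" means these few. Any claim that something is new, unique, unknown or untested is made for them only; others in the source may bear on it.

Compound 1 `N/C(=N\NC(=S)N1CCCCCC1)c1ccccn1` and compound 2 `N/C(=N\NC(=S)N1CCOCC1)c1ccccn1` share the same core and differ only in the saturated ring at one end. In a functional assay on A-375 cells (Homo sapiens) for cytotoxicity, read by MTT assay, with a stated time of 72 h, tested at 10 uM (on this read-out lower numbers stand for less inhibition of growth and higher numbers for more inhibition of growth at the one concentration tested), compound 1 gives 86.5%, while compound 2 gives 18.3%. This places compound 2 at the lowest of the two numbers, far beyond the scatter from compound 1. Compound 3 `Cc1ccnc(/C(N)=N/NC(=S)N2CCOCC2)c1` keeps the ring of compound 2 and alters the other ring: methyl in place of hydrogen on an aromatic carbon. For the measured compounds named here, no pair of measured compounds shows this change, so nothing measured tells its size. Such a small change is expected to move the read-out only a little, within the scatter or just beyond it. The step in this assay is therefore expected to be a number 6.7 percentage points higher from compound 2 to compound 3 (within the scatter). Compound 3 is estimated to give 25% in this assay, with a range from 5% to 50%.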

Compound 3, percent growth inhibition at one concentration: 86%
Beside the measured number, compound 3's estimate is 61 percentage points below it, and the stated range ends below it.
By their numbers in this assay, from the lowest: compound 2; then compounds 3 and 1 (each within the scatter of the next).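

In this assay, methyl in place of hydrogen on an aromatic carbon, opposite the ring nitrogen, gives a number 67.7 percentage points higher from compound 2 to compound 3 (beyond the scatter), so this position is far from silent. For the compounds shown here, the earlier compounds showed only that changing the saturated ring can go with a large difference; this step shows that a change of a single carbon atom on the other ring can do so too, with the saturated ring left as it is. Nothing available here explains why so small a change has so large an effect.

As far as these compounds go, whether the step is special to methyl or would also appear with an ethyl group, an amine or a chlorine atom at this position remains open. Also open, from the compounds shown here alone, is whether the same methyl would have any such effect alongside the saturated ring of compound 1.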